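A few compounds are considered here, and "the series" means these few. Any claim that something is new, unique, unknown or untested is made for them only; others in the source may bear on it.

Measured compounds:
Compound 1, `NC(=S)N1CCc2c(OCCCCCOc3ccc(Cl)cc3)cccc21`, in an ADME assay on Huh-7 cells (Homo sapiens) for cytotoxicity (on this read-out lower numbers stand for higher toxicity in this test and higher numbers for lower toxicity in this test), gives > 50000 nM, which is a limit of the assay and not a number.
Compound 2, `O=C(NC(=S)N1CCc2c(OCCCCCOc3ccc(Cl)cc3)cccc21)c1ccc([N+](=O)[O-])cc1`, in this assay gives 13600 nM.
Compound 3, `N#Cc1ccc(C(=O)NC(=S)N2CCc3c(OCCCCCOc4ccc(Cl)cc4)cccc32)cc1`, in this assay gives > 50000 nM, again a limit of the assay rather than a number.

Compound 1 thus stands at the limit, and it is not alone there: the limit of > 50000 nM in this assay, at which 2 of the 3 values shown sit. Compound 4, `O=C(CCc1ccccc1)NC(=S)N1CCc2c(OCCCCCOc3ccc(Cl)cc3)cccc21`, differs from compound 1 in one place: phenethylcarbonyl in place of hydrogen on an amide-type nitrogen. Within the data shown here, two measured steps bear on a change of this kind, each putting a carbonyl-bearing group on the same nitrogen. The first is an at least 3.6-fold lower number from compound 1 to compound 2 (0.56 log units; beyond the scatter), which shows that such a group can move the read-out beyond the scatter. The second is a step that the two limits leave unreadable from compound 1 to compound 3, since both ends of that step are limits (the limit of > 50000 nM in this assay, at which 2 of the 3 values shown sit). Taken together, they leave the direction for compound 4 open: one acyl group lowered the number, the other left the compound at the limit. The expectation for compound 4 is therefore a modest step at most, an at least 1.6-fold lower number from compound 1 to compound 4 (0.22 log units; that floor lies within the scatter), with a real chance that only a limit is reported again. The estimate for compound 4 in this assay is 30000 nM, expected to fall between 8000 nM and 50000 nM.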

Compound 4, half-maximal cytotoxic concentration: > 50000 nM
Compound 4: only a limit was reported; the forecaster's own chance of this, stated with the estimate: 50%; at least 1.6-fold (0.22 log units) between middle value and limit.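

Phenethylcarbonyl on the amide-type nitrogen, like 4-cyanophenylcarbonyl before it, does not bring a measured number into reach: in this assay compound 4 gives > 50000 nM, which is a limit of the assay and not a number. Phenethyl in place of 4-nitrophenyl on the carbonyl carbon gives an at least 3.6-fold higher number from compound 2 to compound 4 (0.56 log units; beyond the scatter), so among the acyl groups shown the lower number goes with 4-nitrophenylcarbonyl alone, not with acylation of this nitrogen as such, and compound 2 is the only acylated compound that departs from the limit. The steps among the other compounds cannot be read, because both ends of each are limits: the limit of > 50000 nM in this assay, at which 3 of the 4 values shown sit.

As far as these compounds go, how compound 1, compound 3 and compound 4 truly stand relative to one another therefore remains unknown, and a real difference among them could lie hidden beyond the limit. Also open, from the compounds shown here alone, is whether the lower number depends on the nitro group itself, or whether a phenylcarbonyl group carrying an amine or a carboxylic acid in that place would lower the number as well.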